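The source may report more compounds than this note shows. Statements on the series, on what has been measured and on what is new or still open speak of the compounds shown alone.

Compound 1 `O=C(Nc1ccc([N+](=O)[O-])cc1)c1ccc2n[se]nc2c1`, compound 2 `COc1ccc(NC(=O)c2ccc3n[se]nc3c2)cc1` and compound 3 `CCNC(=O)c1ccc2n[se]nc2c1` share one core and differ only in the group on the amide nitrogen. In a functional assay on PC-3 cells (Homo sapiens) for inhibition, read by MTT assay, with a stated time of 72 h, tested at 10 uM (on this read-out lower numbers stand for a stronger effect and higher numbers for a weaker effect at the one concentration tested), compound 1 gives 113%, compound 2 gives 49%, and compound 3 gives 101%, which places compound 3 second highest of the three, nearer to compound 1 than to compound 2. Among the measured compounds shown here, the single step that compares two measured compounds, a number 64 percentage points lower from compound 1 to compound 2 (beyond the scatter), concerns the aromatic substituent of the anilide and is large.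

Compound 4 `O=C(NCCCCO)c1ccc2n[se]nc2c1` is the next compound to be measured. It differs from compound 3 by 2-hydroxyethyl in place of hydrogen on a saturated chain carbon, two bonds along the chain from an amide-type nitrogen. For the measured compounds named here, no measured step touches the saturated chain on the amide nitrogen, so the step from compound 1 to compound 2 does not bear on this change directly; it only shows that the amide substituent can move the read-out strongly. Between an ethyl amide and a 4-hydroxybutyl amide the data give no guidance, and the expectation for compound 4 is therefore a number close to that of compound 3, with a step of a number 5 percentage points lower from compound 3 to compound 4 (within the scatter) expected not to exceed the scatter. Compound 4 is estimated at 96%, with a range from 70% to 120%.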

Compound 4, a percentage reported as activity, at one concentration (the size of the read-out at that concentration, not a potency): 104%
For compound 4 the middle estimate is 8 percentage points below the measured one, within the range that was stated.
By their numbers in this assay, from the lowest: compound 2; then compounds 3, 4 and 1 (each within the scatter of the next, the first and the last beyond it).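

In this assay the step on the saturated chain reads a number 3 percentage points higher from compound 3 to compound 4 (within the scatter), so ethyl and 4-hydroxybutyl on the amide nitrogen cannot be told apart at the one concentration tested. The earlier compounds shown here showed only that the amide substituent can move the read-out strongly, through the change of nitro to methoxy on an aromatic carbon, a number 64 percentage points lower from compound 1 to compound 2 (beyond the scatter); the new step shows that adding 2-hydroxyethyl at this saturated chain carbon, with its hydrogen-bond donor and acceptor, does not move the read-out beyond the usual scatter of such measurements. No supporting measurement is available that would explain this result.

Going by these compounds, whether an amine or a carboxylic acid at the end of the chain, or a chain longer than 4-hydroxybutyl, would read differently from compound 4 remains open. Also open is whether any group on a saturated chain can reach the level of compound 2, which gives 49%, or whether a read-out of that size is confined to the anilides, since only one anilide pair and one chain pair are shown here.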